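Trading a Ring for an Open Chain

A few compounds are considered here, and "the series" means these few. Any claim that something is new, unique, unknown or untested is made for them only; others in the source may bear on it.

Of the compounds shown here, two sharing one core have been measured in a functional assay on brain (Rattus norvegicus, strain Wistar) for inhibition; a higher number here means a weaker inhibitor, a lower number a stronger inhibitor. Compound 1 `CCCCCc1ccc(-c2c(C)[nH]c(=O)n2C2CCCCC2)cc1` gives 10600 nM, and compound 2 `Cc1[nH]c(=O)n(C2CCCCC2)c1-c1ccc(C2CCCCC2)cc1` gives 28900 nM, the higher number of the pair and so the weaker inhibitor. For the measured compounds named here, only one measured step exists, a 2.7-fold higher number from compound 1 to compound 2 (0.44 log units; beyond the scatter), and it is modest: cyclohexyl in place of pentyl on an aromatic carbon. Compound 3 `CCCCCCCCOc1ccc(-c2c(C)[nH]c(=O)n2C2CCCCC2)cc1` has not yet been measured. It carries octyloxy in place of cyclohexyl on an aromatic carbon, (octyloxy in place of cyclohexyl on an aromatic carbon). This swaps the ring for an open chain, the reverse of the change from pentyl to cyclohexyl, so a move toward a lower number is expected. Going by the values given here, the guide is loose, since no measured compound carries octyloxy. The expected step is a 3.2-fold lower number from compound 2 to compound 3 (0.51 log units; beyond the scatter). For compound 3 the estimate is 9000 nM, with an expected range from 2500 nM to 30000 nM.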

Compound 3, half-maximal inhibitory concentration: 8500 nM
Compound 3: the middle estimate sits 1.1-fold (0.02 log units) above what was measured, and the stated range covers the measured number.
By their numbers in this assay, from the lowest: compounds 3 and 1 (each within the scatter of the next); then compound 2.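

In this assay, putting octyloxy in place of cyclohexyl gives a 3.4-fold lower number from compound 2 to compound 3 (0.53 log units; beyond the scatter) and so reverses the loss seen with cyclohexyl, which means that compound 2, with its ring, now stands apart from two different open chains rather than one. Octyloxy in place of pentyl gives a 1.2-fold lower number from compound 1 to compound 3 (0.10 log units; within the scatter) and this step lies within the scatter, so at this position, para to a large group, the two chains cannot be told apart even though only octyloxy carries an oxygen. Nothing available explains why the ring and the chains differ here.

Going by these compounds, whether the oxygen of octyloxy matters stays open, as a plain octyl chain would be needed to separate it from chain length. Also open, on these data alone, is how an amine or a carboxylic acid at this position would compare with these chains.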